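The source may report more compounds than this note shows. Statements on the series, on what has been measured and on what is new or still open speak of the compounds shown alone.

Measured in a functional assay on CHO-K1 cells for antagonist activity at transient receptor potential cation channel subfamily V member 1 (Homo sapiens), read by FLIPR (a higher number here means a weaker inhibitor, a lower number a stronger inhibitor), so far:
compound 1 `CC1CCC(Nc2nc(C(F)(F)F)ccc2CNC(=O)C(C)c2ccc(NS(C)(=O)=O)c(F)c2)CC1` gives 1130 nM
compound 2 `CC(C(=O)NCc1ccc(C(F)(F)F)nc1N1CCC(C(=O)c2ccc(F)cc2)CC1)c1ccc(NS(C)(=O)=O)c(F)c1` gives 990 nM

Going by the values given here, only these two compounds have numbers, and no single-change step between them is on record. Compound 2 stands level with compound 1 in this assay: the two numbers differ by less than the usual scatter, so neither can be called the stronger inhibitor. Compound 3 `CC(C(=O)NCc1ccc(C(F)(F)F)nc1N1CCC(O)CC1)c1ccc(NS(C)(=O)=O)c(F)c1` is not yet measured. It differs from compound 2 in one place: hydroxy in place of (4-fluorophenyl)carbonyl on a saturated ring carbon. Among the compounds with values here, nothing among the measured pairs shows how a change of this kind moves the read-out, so the expected size of the step rests on the nature of the change alone. A larger group is traded for a single hydroxy, and a modest weakening, somewhat beyond the scatter, is the expectation here. Compound 3 is therefore expected to give 2500 nM in this assay, within the range 800 nM to 8000 nM. This expected value corresponds to a step of a 2.5-fold higher number from compound 2 to compound 3 (0.40 log units; beyond the scatter).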

Compound 3, half-maximal inhibitory concentration: "not active" (no number reported)
The entry for compound 3 holds no number; there is nothing to compare the estimate with.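

In this assay, going by these compounds alone, compound 3 is recorded as "not active" without a number, so no step from compound 2 to compound 3 can be read. Nothing available explains this result. The compounds shown leave open how far hydroxy in place of (4-fluorophenyl)carbonyl moves the read-out.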